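The compounds below may be only part of what the source reports. "The series", "measured", "known", "first", "only" and "open" are said of these compounds alone.

Measured so far:
compound 1 `C[C@H](N)C(=O)NS(=O)(=O)OC[C@H]1OC[C@@H](n2cnc3c(N)ncnc32)[C@H](O)[C@@H]1O` — 300 nM
compound 2 `CC[C@H](C)[C@H](N)C(=O)NS(=O)(=O)OC[C@H]1O[C@@H](n2cnc3c(N)ncnc32)[C@H](O)[C@@H]1O` — 5600 nM
compound 3 `CSCC[C@H](N)C(=O)NS(=O)(=O)OC[C@H]1OC[C@@H](n2cnc3c(N)ncnc32)C[C@@H]1O` — 5500 nM

In a functional assay on PBMC cells (Homo sapiens) for inhibition (a lower number here means a stronger inhibitor, a higher number a weaker inhibitor), compound 2 gives 5600 nM, the highest number among the three. Compound 3, at 5500 nM, lies within the usual scatter of it, so the two cannot be told apart on these data; compound 1, at 300 nM, sits well beyond the scatter and is the clearly stronger inhibitor. Compound 4 `CC(C)[C@H](N)C(=O)NS(=O)(=O)OC[C@H]1O[C@@H](n2cnc3c(N)ncnc32)[C@H](O)[C@@H]1O` has not yet been measured in this assay. It differs from compound 2 in one place: hydrogen in place of methyl on a saturated chain carbon, three bonds along the chain from an amine nitrogen and a carbonyl carbon. Going by the values given here, no measured pair shows this change, so its size cannot be read from the numbers at hand. Only a small step is expected, in either direction or none beyond the scatter. Compound 4 is therefore expected to give about 5000 nM in this assay, between 2000 nM and 14000 nM, a step of a 1.1-fold lower number from compound 2 to compound 4 (0.05 log units; within the scatter) that is expected to stay within the scatter.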

Compound 4, half-maximal inhibitory concentration: 5600 nM
Beside the measured number, compound 4's estimate is 1.1-fold (0.05 log units) below it; the measured number falls inside the stated range.
By their numbers in this assay, from the lowest: compound 1; then compounds 3, 2 and 4 (each within the scatter of the next).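

Going by these compounds alone, replacing sec-butyl with isopropyl gives no change at the digits printed from compound 2 to compound 4 (within the scatter) in this assay, the first pair here to isolate a single change. At this saturated chain carbon, the methyl can therefore give way to hydrogen without a change beyond the scatter in this pair. Nothing at hand gives a cause for this result.

From the compounds shown here alone, whether a longer chain, an amine or a carboxylic acid at this carbon would behave the same remains open. Compound 1 differs from compound 2 and compound 4 in more than one place, so its lower number cannot be assigned to any single change.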